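A methoxy group moves, with only limits to go on

This account rests on a few compounds, and the source may have more. Where it says the series, first, only, none or still open, it means among the compounds named here.

In a functional assay on HUVEC cells (Homo sapiens) for inhibition, with stated times of 2 h and 72 h (a higher number here means a weaker inhibitor, a lower number a stronger inhibitor), compound 3 (`COc1cccc(Nc2nn(C)c3cc(Oc4ccnc5cc(OC)c(OC)cc45)ccc23)c1`) gives > 1000 nM as a limit of the assay and not a number. Compound 1 (`COc1cc2nccc(Oc3ccc4c(NC(=O)c5cc(C(F)(F)F)cc(C(F)(F)F)c5)nn(C)c4c3)c2cc1OC`) gives > 1000 nM as a limit too. Compound 2 (`COc1cc2nccc(Oc3ccc4c(NC(=O)C5CC5)nn(C)c4c3)c2cc1OC`) also gives > 1000 nM as a limit. The whole picture so far is the limit of > 1000 nM in this assay, at which 3 of the 3 values shown sit, and no exact potency is known for any of these compounds.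

Compound 4 (`COc1ccc(Nc2nn(C)c3cc(Oc4ccnc5cc(OC)c(OC)cc45)ccc23)cc1`) keeps the shared core and differs from compound 3 in one group. The change is 4-methoxyphenyl in place of 3-methoxyphenyl on a nitrogen on an aromatic ring and, in words, it puts 4-methoxyphenyl in place of 3-methoxyphenyl on a nitrogen on an aromatic ring.

Among the measured compounds shown here, the one measured step that bears on this nitrogen is a step that the two limits leave unreadable from compound 2 to compound 3 and it offers no size to carry over. Compound 1, compound 2 and compound 3 carry different groups at that place, yet none of them gives a number. A further reading at the limit is therefore the likeliest result for compound 4.

The expected change is a step that the limit leaves unreadable from compound 3 to compound 4 in this assay with no direction favoured and nothing expected beyond the scatter. The estimate for compound 4 is 2000 nM (expected range 700 nM to 10000 nM) in this assay.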

Compound 4, half-maximal inhibitory concentration: > 1000 nM
Compound 4 gave a limit, no number (the forecaster's own chance of this, stated with the estimate: 85%); the middle value does not contradict the limit.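

In this assay compound 4 gives > 1000 nM as a limit of the assay and not a number. No step can be read from compound 3 to compound 4 or from compound 2 to compound 4, and the whole picture stays the same: the limit of > 1000 nM in this assay, at which 4 of the 4 values shown sit.

The compounds shown leave open whether any group on this nitrogen gives a measurable potency.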